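A few compounds are considered here, and "the series" means these few. Any claim that something is new, unique, unknown or untested is made for them only; others in the source may bear on it.

Measured compounds:
- compound 1 `CN(C)CCn1cnnc1-c1cc(Oc2ccc(NC(=O)N/N=C/c3c[nH]c4ccccc34)cc2F)ccn1`: in an ADME assay on WI-38 cells (Homo sapiens) for cytotoxicity, read by MTT assay, with a stated time of 72 h (on this read-out lower numbers stand for stronger inhibition and higher numbers for weaker inhibition), compound 1 gives 3620 nM
- compound 2 `CN(C)CCn1cnnc1-c1cc(Oc2ccc(NC(=O)N/N=C/c3ccc(O)c(Br)c3)cc2F)ccn1`: in this assay compound 2 gives 5560 nM

Compound 2 holds the highest of the two numbers in this assay, with compound 1 nearest; the two values lie within the scatter of each other, so no order between them can be read from the data.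

Going by the values given here, the one step available at the same position is a 1.5-fold higher number from compound 1 to compound 2 (0.19 log units; within the scatter), which exchanged the group on the carbon with a double bond to nitrogen without moving the number beyond the scatter.

Compound 3 `CN(C)CCn1cnnc1-c1cc(Oc2ccc(NC(=O)N/N=C/c3ccc(F)cc3F)cc2F)ccn1` differs from compound 2 at that same position: 2,4-difluorophenyl in place of 3-bromo-4-hydroxyphenyl on a carbon with a double bond to nitrogen. Among the compounds with values here, the only step that bears on this change is the one from compound 1 to compound 2, and it was within the scatter. On that basis the expected step is none beyond the scatter in this assay, with no direction to prefer; the expected step is a 1.1-fold lower number from compound 2 to compound 3 (0.05 log units; within the scatter). For compound 3 the estimate in this assay is 5000 nM, with a range from 2000 nM to 14000 nM.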

Compound 3, half-maximal inhibitory concentration: 5030 nM
Estimate against measurement, compound 3: 1.0-fold (0.00 log units) below, within the range that was stated.
By their numbers in this assay, from the lowest: compounds 1, 3 and 2 (each within the scatter of the next).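

In this assay, 2,4-difluorophenyl in place of 3-bromo-4-hydroxyphenyl gives a 1.1-fold lower number from compound 2 to compound 3 (0.04 log units; within the scatter), and the same group in place of 1H-indol-3-yl gives a 1.4-fold higher number from compound 1 to compound 3 (0.14 log units; within the scatter), so all three groups compared on the carbon with a double bond to nitrogen now lie within the scatter of one another. The new information is that this holds for a group with 0 hydrogen-bond donors and 0 hydrogen-bond acceptors as well as for 3-bromo-4-hydroxyphenyl, with 1 of each, so the loss of the hydroxyl and the bromine, with fluorine entering, leaves no step beyond the scatter. No measured evidence bears on why the numbers stay so close at this position.

Going by these compounds, all three groups at this position are aromatic, so it remains open whether an aliphatic amine, a carboxylic acid or a longer alkyl chain on the same carbon would stay within the scatter. Every comparison here also sits at this one position, which leaves open whether a change elsewhere on the shared core would move the number in this assay beyond the scatter.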